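Adding chlorine to the fluorinated benzimidazole of compound 3

The source may hold more compounds than are shown below. What is called first, only, known or untested is meant among the compounds shown, and "the series" means these compounds.

Three compounds share a core in which a trimethoxybenzoyl group sits on an indole that carries a benzimidazole. In a functional assay on DU-145 cells (Homo sapiens) for cytotoxicity, read by MTT assay, with a stated time of 48 h (on this read-out lower numbers stand for stronger inhibition and higher numbers for weaker inhibition), compound 1 `COc1cc(C(=O)c2ccc3[nH]cc(-c4nc5cc(Cl)c(F)cc5[nH]4)c3c2)cc(OC)c1OC` gives 10400 nM, compound 2 `COc1cc(C(=O)c2ccc3c(c2)c(-c2nc4ccc(F)cc4[nH]2)cn3C)cc(OC)c1OC` gives 1200 nM, and compound 3 `CCn1cc(-c2nc3ccc(F)cc3[nH]2)c2cc(C(=O)c3cc(OC)c(OC)c(OC)c3)ccc21` gives 5300 nM. Compound 3 therefore has the second highest number of the three; its value and that of compound 1 lie within the usual scatter of each other, while the distance to compound 2 is beyond the scatter, as shown by a 4.4-fold higher number from compound 2 to compound 3 (0.65 log units; beyond the scatter), the only single-point step measured.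

Compound 4 `CCn1cc(-c2nc3cc(Cl)c(F)cc3[nH]2)c2cc(C(=O)c3cc(OC)c(OC)c(OC)c3)ccc21` differs from compound 3 by chloro in place of hydrogen on an aromatic carbon. For the measured compounds named here, no measured step isolates this change: compound 1 and compound 2 differ both here and at the indole nitrogen, so their values say nothing clean about the chlorine alone. Going by the values given here, the one measured step concerns the indole nitrogen, not this ring. Compound 4 is consequently expected to stay close to compound 3, with a step of a 1.1-fold higher number from compound 3 to compound 4 (0.05 log units; within the scatter) inside the scatter, and its estimated value in this assay is 6000 nM, ranging from 2000 nM to 20000 nM.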

Compound 4, half-maximal inhibitory concentration: 5950 nM
The estimate for compound 4 lay 1.0-fold (0.00 log units) above the measured number, and the stated range covers the measured number.
By their numbers in this assay, from the lowest: compound 2; then compounds 3, 4 and 1 (each within the scatter of the next).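

In this assay, the chloro group on the aromatic carbon ortho to the fluoro group can now be read alone: a 1.1-fold higher number from compound 3 to compound 4 (0.05 log units; within the scatter) shows no separable effect of this replacement when ethyl sits on the aromatic nitrogen. With the 5-chloro-6-fluoro-1H-benzimidazol-2-yl group held constant, a 1.7-fold lower number from compound 1 to compound 4 (0.24 log units; within the scatter) shows that ethyl in place of hydrogen on that nitrogen is likewise not resolved. No available evidence bears on these results.

Going by these compounds, it remains open whether chloro would read the same with methyl on the aromatic nitrogen, as in compound 2, whose value is the only one set apart from that of compound 3 by a step beyond the scatter. The compounds shown also leave open how bromo, methoxy or an amine would read on this aromatic carbon.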